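This account rests on a few compounds, and the source may have more. Where it says the series, first, only, none or still open, it means among the compounds named here.

Compound 1, `CC(=O)c1cccn1CCCN1CCN(c2ccc(F)cc2)CC1`, was tested in a functional assay on the whole organism (Abdomen, strain Swiss) for inhibition, with Mus musculus as the target, with stated times of 30 min, 10 min and 5 min, at a dose of 40 mg/kg by the oral route (on this read-out higher numbers stand for a stronger effect at the one dose given and lower numbers for a weaker effect), where compound 1 gives 38%. Compound 2, `CC(=O)c1cccn1CCCN1CCN(c2cccc(Cl)c2)CC1`, differs from compound 1 in one place: 3-chlorophenyl in place of 4-fluorophenyl on an amine nitrogen in a ring. In this assay compound 2 gives 54%, so that the change produced a number 16 percentage points higher from compound 1 to compound 2 (beyond the scatter).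

Compound 3, `O=c1occ(-c2ccccc2)n1CCCN1CCN(c2ccc(F)cc2)CC1`, carries a different core; how its core differs from that of compound 1 is not broken down here. In this assay compound 3 gives 34%. The difference between compound 3 and compound 2 is beyond the scatter, whereas compound 3 and compound 1 lie within the scatter of each other.

Compound 4, `O=c1occ(-c2ccccc2)n1CCCN1CCN(c2cccc(Cl)c2)CC1`, has not yet been measured. It differs from compound 3 by 3-chlorophenyl in place of 4-fluorophenyl on an amine nitrogen in a ring. The place of this change is described in the same words as for the change from compound 1 to compound 2, so the two are the same change, applied here to the core of compound 3 rather than to the core of compound 1. Because the earlier change gave a number 16 percentage points higher from compound 1 to compound 2 (beyond the scatter), a step of similar size is expected for compound 4, namely a number 14 percentage points higher from compound 3 to compound 4 (beyond the scatter). Since compound 3 stands at 34%, the value for compound 4 is estimated at 48%, with a range from 32% to 64%, the width allowing for the change being carried over to a different core and for the usual scatter.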

Compound 4, a percentage reported as inhibition, in the whole organism at one dose (the size of the read-out at that dose, not a potency): 38%
Estimate against measurement, compound 4: 10 percentage points above, within the range that was stated.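

In this assay, putting 3-chlorophenyl in place of 4-fluorophenyl on the core of compound 3 gave a number 4 percentage points higher from compound 3 to compound 4 (within the scatter), while the same change on the core of compound 1 gave a number 16 percentage points higher from compound 1 to compound 2 (beyond the scatter). Set side by side, the two steps cannot be told apart: the same change on two cores in this assay, a number 16 percentage points higher (beyond the scatter) from compound 1 to compound 2 and a number 4 percentage points higher (within the scatter) from compound 3 to compound 4, 12 percentage points apart, within the scatter of two such steps This shows no measurable dependence of the change on the core, but it does not show that the gain carries over, as only the step on the core of compound 1 lies beyond the scatter and each core offers just one pair of compounds at a single dose.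

The compounds shown leave open how a 3-fluorophenyl or a 4-chlorophenyl group on the same amine nitrogen would read in this assay, and such groups would help separate the effect of the halogen from that of its place on the phenyl ring. Also open, on these data alone, is whether the change would behave the same way with a longer chain linking the core to the ring that carries the amine nitrogen.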